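The source may hold more compounds than are shown below. What is called first, only, known or untested is meant among the compounds shown, and "the series" means these compounds.

Measured in a functional assay on MGC-803 cells (Homo sapiens) for inhibition, read by MTT assay, with a stated time of 48 h; on this read-out lower numbers stand for stronger inhibition and higher numbers for weaker inhibition:

- Compound 1 `C/C=C/C=C/C(=O)N(Cc1ccc(OC)c(O)c1)c1cc(OC)c(OC)c(OC)c1`: 140 nM
- Compound 2 `COc1ccc(CN(C(=O)CN=[N+]=[N-])c2cc(OC)c(OC)c(OC)c2)cc1O`: 120 nM

Compound 2 stands level with compound 1, since their two numbers lie within the scatter of each other. The next compound to be tested, compound 3 `COc1ccc(CN(C(=O)CCCCCl)c2cc(OC)c(OC)c(OC)c2)cc1O`, keeps the core of compound 2 and changes only the chain on the carbonyl. There, 3-chloropropyl takes the place of azido on a saturated chain carbon bound to a carbonyl carbon: 3-chloropropyl in place of azido on a saturated chain carbon bound to a carbonyl carbon. Read one bond further out, azidomethyl becomes 4-chlorobutyl.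

Among the measured compounds shown here, only one measured step bears on this change: a 1.2-fold lower number from compound 1 to compound 2 (0.07 log units; within the scatter). It put azidomethyl in place of penta-1,3-dien-1-yl on a carbonyl carbon, so it is a swap in the same part of the molecule, and it stayed within the scatter. For the measured compounds named here, it is a single step, and no measured compound carries a chlorine-bearing chain, so the evidence is thin and the range must stay wide. No change beyond the scatter is expected in this assay, and the expected size is a 1.3-fold higher number from compound 2 to compound 3 (0.10 log units; within the scatter). Compound 3 is estimated at 150 nM, with an expected range of 50 nM to 450 nM.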

Compound 3, half-maximal inhibitory concentration: 540 nM
Compound 3: middle estimate off by 3.6-fold (0.56 log units), on the low side; measured number outside the range, above it.
By their numbers in this assay, from the lowest: compounds 2 and 1 (each within the scatter of the next); then compound 3.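

Up to now the chain on the carbonyl looked free to vary, since penta-1,3-dien-1-yl and azidomethyl gave numbers within the scatter of each other. In this assay, putting 3-chloropropyl in place of azido on a saturated chain carbon bound to a carbonyl carbon gives a 4.5-fold higher number from compound 2 to compound 3 (0.65 log units; beyond the scatter) and so marks the first real loss of inhibition at this position, though a modest one. Measured against the dienyl chain, 4-chlorobutyl gives a 3.9-fold higher number from compound 1 to compound 3 (0.59 log units; beyond the scatter), so compound 3 is the weakest of the three and this part of the molecule does affect the read-out; nothing available explains why.

The compounds shown do not separate the terminal chlorine from the length of the chain, since compound 3 differs from the other two in both at once, and a plain butyl chain on the carbonyl would pull these two apart. On these data alone, it also stays open how a chain of the same length ending in an amine or a carboxylic acid would compare with 4-chlorobutyl in this assay.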